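Swapping the aryl group on the acetal carbon

The source may hold more compounds than are shown below. What is called first, only, known or untested is meant among the compounds shown, and "the series" means these compounds.

Compound 1 `O=C(O)CC/C=C\CC1COC(c2cccnc2)OC1c1cccnc1` gives 220 nM in an assay for inhibition of Thromboxane-A synthase (Homo sapiens), using microsomes; a higher number here means a weaker inhibitor, a lower number a stronger inhibitor.
Compound 2 `CC(C)(Oc1ccccc1)C1OCC(C/C=C\CCC(=O)O)C(c2cccnc2)O1` gives 52 nM in this assay.

Compound 2 has the lowest number of the two measured compounds, which in this assay means the stronger inhibitor; its nearest neighbour is compound 1, and the difference between them is a 4.2-fold lower number from compound 1 to compound 2 (0.63 log units; beyond the scatter).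

The next compound, compound 3 `CC(C)(Cc1ccc(F)cc1C#N)C1OCC(C/C=C\CCC(=O)O)C(c2cccnc2)O1`, has not yet been measured in this assay. It differs from compound 2 only at one spot: a group of 10 heavy atoms (8 carbon, 1 nitrogen, 1 fluorine; one six-membered aromatic ring of carbon only) in place of a group of 7 heavy atoms (6 carbon, 1 oxygen; one six-membered aromatic ring of carbon only), on a saturated chain carbon bound to two saturated chain carbons and a saturated ring carbon

Among the compounds with values here, the one measured step, a 4.2-fold lower number from compound 1 to compound 2 (0.63 log units; beyond the scatter), changed the same place where compound 3 now differs, but it exchanged a different pair of groups, so it shows that this place tolerates a change without loss, not what this particular exchange will do. Within the data shown here, with no closer precedent, the expected step of a 1.2-fold higher number from compound 2 to compound 3 (0.06 log units; within the scatter) for compound 3 is small and within the scatter, in either direction. Compound 3 is therefore estimated at 60 nM, with a range from 20 nM to 180 nM.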

Compound 3, half-maximal inhibitory concentration: < 10 nM
Compound 3 was reported as a limit (the forecaster's own chance of this, stated with the estimate: 5%); middle value at least 6.0-fold (0.77 log units) from the limit.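

Compound 3 gives < 10 nM in this assay, and this value is a limit of the assay, not a number. At the saturated chain carbon bound to two saturated chain carbons and a saturated ring carbon, replacing phenoxy with the group of 10 heavy atoms, which carries a fluorine and a nitrile, gives an at least 5.2-fold lower number from compound 2 to compound 3 (0.71 log units; beyond the scatter), so the exchange of one group with a six-membered aromatic carbon ring for another moves the number beyond the scatter, which shows that this place does more than tolerate change. The size of this step is only a bound, and how far compound 3 lies past the limit cannot be read: the limit of < 10 nM in this assay, at which 1 of the 3 values shown sits.

The step removes the oxygen of phenoxy and adds both the fluorine and the nitrile at once, so the compounds shown cannot say which of these changes matters, or whether all of them are needed. As far as these compounds go, it also remains open whether a plain benzyl group, a chlorine in place of the fluorine, or an amide in place of the nitrile would give a similar number.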